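This account rests on a few compounds, and the source may have more. Where it says the series, first, only, none or still open, it means among the compounds named here.

Measured in a functional assay on H184B5F5/M10 cells (Homo sapiens) for antiproliferative activity, read by XTT assay, with a stated time of 72 h; a higher number here means a weaker inhibitor, a lower number a stronger inhibitor:
- compound 1 `COc1ccc(-c2cc3ccccc3nc2C=O)cc1`: > 10000 nM, a limit
- compound 2 `COc1ccc(-c2cc3ccccc3nc2/C=C/C(=O)c2ccc(F)cc2)cc1`: > 10000 nM, a limit

Compound 2 has no numerical value, only a limit. It sits at the limit of > 10000 nM in this assay, at which 2 of the 2 values shown sit.

Compound 3 `COc1ccc(C(=O)/C=C/c2nc3ccccc3cc2-c2ccc(OC)cc2)cc1` differs from compound 2 by one change, methoxy in place of fluoro on an aromatic carbon, para to a large group: methoxy in place of fluoro on an aromatic carbon.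

For the measured compounds named here, no measured step is available for comparison. In this assay, the estimated a number no higher from compound 2 to compound 3 (the limit leaves the size open) is expected to stay within the scatter, with no direction favoured. For compound 3, the expected value is 10000 nM, with an estimated range of 3000 nM to 30000 nM.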

Compound 3, half-maximal inhibitory concentration: > 10000 nM
Compound 3: a limit, no number; the forecaster's own chance of this, stated with the estimate: 75%; the middle value lies on the limit itself.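

Compound 2 and compound 3 are both limits in this assay, and no step between them can be read: the limit of > 10000 nM in this assay, at which 3 of the 3 values shown sit.

The compounds shown leave open whether methoxy in place of fluoro changes the read-out in this assay at all, and what number any of them would give.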